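A few compounds are considered here, and "the series" means these few. Any claim that something is new, unique, unknown or untested is made for them only; others in the source may bear on it.

Measured compounds:
`CCCCCCCCCCCCCCCC(=O)OC[C@H](CSC[C@H](NC(=O)CC[C@H](N)C(=O)O)C(=O)NCC(=O)OC(C)C)OC(=O)CCCCCCCCCCCCCCC` — compound 1, > 1000 nM in a functional assay on HEK293 cells for agonist activity at Toll-like receptor 2 (Homo sapiens), read by spectrophotometry, with a stated time of 12 h; a higher number here means that more compound is needed for the effect, a lower number that less compound is needed
`CCCCCCCCCCCCCCCC(=O)OC[C@H](CSC(C)(C)[C@@H](N)C(=O)N[C@@H](CO)C(=O)OC)OC(=O)CCCCCCCCCCCCCCC` — compound 2, > 1000 nM in this assay

Compound 1 is reported only as a limit of this assay, > 1000 nM, not as a number. Compound 2 likewise sits only at a limit, > 1000 nM, so that both values shown rest on the limit of > 1000 nM in this assay, at which 2 of the 2 values shown sit, and no numerical potency is known for either. Within the data shown here, no step between measured compounds can be computed here.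

Compound 3, `CCCCCCCCCCCCCCCC(=O)OC[C@H](CSC(C)(C)[C@H](N)C(=O)N[C@@H](CO)C(=O)O)OC(=O)CCCCCCCCCCCCCCC`, is not yet measured. Compared with compound 2 it carries amino((1-carboxy-2-hydroxyethyl)carbamoyl)methyl in place of amino((2-hydroxy-1-(methoxycarbonyl)ethyl)carbamoyl)methyl on a saturated chain carbon bound to two saturated chain carbons and a sulfur. Among the measured compounds shown here, since the only value available for compound 2 is a limit, nothing in the data gives the direction or size of a step into a measurable range. The expectation for the step that the limit leaves unreadable from compound 2 to compound 3 is therefore one of no change beyond the scatter, with compound 3 most likely again reported at the limit. For compound 3 the estimate in this assay is 1500 nM, within 500 nM to 6000 nM.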

Compound 3, half-maximal effective concentration: > 1000 nM
Compound 3 gave a limit, no number; the forecaster's own chance of this, stated with the estimate: 80%; the middle value is on the limit's open side.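

Compound 3 is again reported only as a limit, > 1000 nM in this assay. Among these compounds, no step from compound 2 to compound 3 can be read, as both rest on the same limit: the limit of > 1000 nM in this assay, at which 3 of the 3 values shown sit.

The compounds shown leave open what numerical potency any of them has.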